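Swapping Methoxy for Methyl on an Aromatic Ring

The source may report more compounds than this note shows. Statements on the series, on what has been measured and on what is new or still open speak of the compounds shown alone.

Measured so far in a functional assay on NCI-H460 cells (Homo sapiens) for antiproliferative activity; a lower number here means a stronger inhibitor, a higher number a weaker inhibitor
- compound 1 `COc1ccc(N=C2NC(=O)/C(=C\c3ccc(N(C)C)cc3)S2)cc1` gives 1600 nM
- compound 2 `COc1ccc(/C=C2/S/C(=N/c3ccccc3C)NC2=O)cc1` gives 1700 nM

Compound 1 stands level with compound 2, as their two numbers lie within the scatter of each other. Compound 3 `Cc1ccc(N=C2NC(=O)/C(=C\c3ccc(N(C)C)cc3)S2)cc1` keeps the core of compound 1 but has methyl in place of methoxy on an aromatic carbon, para to a large group (methyl in place of methoxy on an aromatic carbon). Among the compounds with values here, no measured step shows this change, so in this assay only a shift within the scatter is expected, with no firm direction. The estimated value for compound 3 is 1800 nM with an expected range from 700 nM to 4500 nM in this measurement.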

Compound 3, half-maximal inhibitory concentration: 820 nM
Beside the measured number, compound 3's estimate is 2.2-fold (0.34 log units) above it; measured number inside the range.
By their numbers in this assay, from the lowest: compounds 3, 1 and 2 (each within the scatter of the next, the first and the last beyond it).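

In this assay, putting methyl in place of methoxy on this aromatic carbon, para to a large group, gives a 2.0-fold lower number from compound 1 to compound 3 (0.29 log units; within the scatter) and so stays level. On the core of compound 1, this position therefore accepts either group, and the hydrogen-bond acceptor counted on methoxy is not needed to hold the number at this level. Nothing available accounts for this step. Going by these compounds, whether an amine, a carboxylic acid or a longer chain at this carbon would also stay level remains open, as does whether this swap behaves alike on another core.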